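Fluorine on the pendant phenyl: a second look

This account rests on a few compounds, and the source may have more. Where it says the series, first, only, none or still open, it means among the compounds named here.

Measured compounds:
compound 1 `COc1cc2c(Oc3ccc(NC(=O)c4cc(-c5ccccc5)ccn4)cc3F)ccnc2cc1OCCCN1CCN(C)CC1`: 150 nM
compound 2 `COc1cc2c(Oc3ccc(NC(=O)c4cc(-c5ccc(F)cc5)ccn4)cc3F)ccnc2cc1OCCCN1CCN(C)CC1`: 510 nM
compound 3 `COc1cc2c(Oc3ccc(NC(=O)c4cc(-c5ccccc5)ccn4)cc3F)ccnc2cc1OCCCN1CCCC1`: 210 nM

All three were tested in a functional assay on MKN-45 cells (Homo sapiens) for cytotoxicity, read by MTT assay, with a stated time of 72 h; on this read-out lower numbers stand for stronger inhibition and higher numbers for weaker inhibition. Compound 3, with 210 nM, holds the second highest of the three numbers; its step from compound 1, a 1.4-fold higher number from compound 1 to compound 3 (0.15 log units; within the scatter), lies within the scatter, whereas its gap to compound 2 lies beyond it. Compound 4 `COc1cc2c(Oc3ccc(NC(=O)c4cc(-c5ccccc5F)ccn4)cc3F)ccnc2cc1OCCCN1CCCC1` differs from compound 3 by fluoro in place of hydrogen on an aromatic carbon, the fluoro entering on an aromatic carbon of a six-membered aromatic ring of carbon only, ortho to a large group; cut one bond further out, the change reads phenyl to 2-fluorophenyl. Within the data shown here, the one measured step that bears on it is the fluoro entering the same ring on going from compound 1 to compound 2, a 3.4-fold higher number from compound 1 to compound 2 (0.53 log units; beyond the scatter), a modest step beyond the scatter toward a higher number. A step of similar direction, though not necessarily the same size, is therefore expected for compound 4, a 2.1-fold higher number from compound 3 to compound 4 (0.33 log units; beyond the scatter). Compound 4 is accordingly estimated at 450 nM, with a likely range of 180 nM to 1100 nM.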

Compound 4, half-maximal inhibitory concentration: 230 nM
The estimate for compound 4 lay 2.0-fold (0.29 log units) above the measured number; the range from low to high includes it.
By their numbers in this assay, from the lowest: compounds 1, 3 and 4 (each within the scatter of the next); then compound 2.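

In this assay, the change to 2-fluorophenyl reads as a 1.1-fold higher number from compound 3 to compound 4 (0.04 log units; within the scatter), so with the pyrrolidin-1-yl group in place, a fluoro ortho to a large group leaves the number where phenyl had it. The rise seen with compound 2 therefore does not hold as a general rule for fluoro on this ring. The same change proves to depend on its setting: the same change on two cores in this assay, a 3.4-fold higher number (0.53 log units; beyond the scatter) from compound 1 to compound 2 and a 1.1-fold higher number (0.04 log units; within the scatter) from compound 3 to compound 4, 3.1-fold (0.49 log units) apart, beyond the scatter of two such steps

The two steps differ both in the ring carbon that takes the fluoro and in the amine, pyrrolidin-1-yl against 4-methylpiperazin-1-yl, so the compounds shown cannot say which of these sets the gap. As far as these compounds go, it also remains open whether 2-fluorophenyl would behave the same way with 4-methylpiperazin-1-yl, and whether chloro or methoxy in the place of this fluoro would leave the number equally undisturbed.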